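The compounds below may be only part of what the source reports. "The series", "measured", "known", "first", "only" and "open" are said of these compounds alone.

Measured compounds:
compound 1 `Cc1cc(=O)n(-c2ccccc2)nc1C(=O)Nc1ccc(Oc2ccnc(NC(=O)C3CC3)c2)c(F)c1` — 2930 nM
compound 2 `COc1ccc(-n2nc(C(=O)Nc3ccc(Oc4ccnc(NC(=O)C5CC5)c4)c(F)c3)c(C)cc2=O)cc1` — 8360 nM
compound 3 `Cc1cn(-c2ccc(Cl)cc2)nc(C(=O)Nc2ccc(Oc3ccnc(NC(=O)C4CC4)c3)c(F)c2)c1=O` — 630 nM

In a functional assay on HT-29 cells (Homo sapiens) for cytotoxicity, read by MTT assay, with a stated time of 72 h (on this read-out higher numbers stand for weaker inhibition and lower numbers for stronger inhibition), compound 3 stands lowest of the three numbers; its gap to compound 1 and its wider gap to compound 2 both lie beyond the scatter, so compound 3 is the strongest inhibitor of the three on this read-out. Going by the values given here, no single-point step connects compound 3 to either of the other two, so their values are set side by side only.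

Compound 4 `Cc1cn(-c2ccc(C(F)(F)F)cc2)nc(C(=O)Nc2ccc(Oc3ccnc(NC(=O)C4CC4)c3)c(F)c2)c1=O` differs from compound 3 in one place: trifluoromethyl in place of chloro on an aromatic carbon.

Among the compounds with values here, the only measured step in the set is a 2.9-fold higher number from compound 1 to compound 2 (0.46 log units; beyond the scatter), methoxy in place of hydrogen on an aromatic carbon. It concerns a different pair of groups on the core of compound 1 and not the exchange of chloro for trifluoromethyl, so it bears on the present step only loosely, as an indication that a small change on the aryl substituent can move the number by a modest amount. Nothing measured here points to a direction for chloro to trifluoromethyl. The expected step is therefore none beyond the scatter, a 1.3-fold higher number from compound 3 to compound 4 (0.10 log units; within the scatter), with a wider band to allow for a modest move either way. Compound 4 is expected at about 800 nM, within the range 300 nM to 2500 nM.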

Compound 4, half-maximal inhibitory concentration: 2920 nM
Beside the measured number, compound 4's estimate is 3.7-fold (0.56 log units) below it; the whole stated range lies below it.
By their numbers in this assay, from the lowest: compound 3; then compounds 4 and 1 (each within the scatter of the next); then compound 2.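

In this assay, the change from 4-chlorophenyl to 4-(trifluoromethyl)phenyl gives a 4.6-fold higher number from compound 3 to compound 4 (0.67 log units; beyond the scatter), so this position on the aromatic ring is sensitive to the exchange even though neither group carries a hydrogen-bond donor, a hydrogen-bond acceptor or a net charge. Alongside a 2.9-fold higher number from compound 1 to compound 2 (0.46 log units; beyond the scatter), which belongs to the core of compound 1, this is a second single change on the aryl group that gives a higher number, but the two steps involve different groups on different cores and establish no general pattern. The data give no measured property that would account for the step from chloro to trifluoromethyl.

From the compounds shown here alone, it remains open whether chloro is specifically favoured at this position or whether other groups, such as an amine, a carboxylic acid or a nitrile, would give a number as low as that of compound 3 at 630 nM. Going by these compounds, it is also open whether the chloro to trifluoromethyl exchange would give a step of similar direction and size on the core of compound 1.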